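The source may report more compounds than this note shows. Statements on the series, on what has been measured and on what is new or still open speak of the compounds shown alone.

Working notes on the series, read in a functional assay on HeLa cells (Homo sapiens) for inhibition, read by sulforhodamine B assay, with a stated time of 48 h; on this read-out lower numbers stand for stronger inhibition of growth and higher numbers for weaker inhibition of growth. Compound 1 (`Cc1ccn2c(CN3CCCCC3)c(-c3ccccc3)nc2n1`) gives 1710 nM, compound 2 (`Cc1ccn2c(CN3CCCC3)c(-c3ccc(O)cc3)nc2n1`) gives 4760 nM and compound 3 (`Cc1ccn2c(CN3CCCCC3)c(C(C)(C)C)nc2n1`) gives 450 nM. Compound 2 therefore has the highest of the three numbers, with both gaps beyond the scatter.

Compound 4 (`Cc1ccn2c(CN3CCCC3)c(-c3ccccc3)nc2n1`) is not yet measured. It differs from compound 2 as follows: hydrogen in place of hydroxy on an aromatic carbon. This is hydrogen in place of hydroxy on an aromatic carbon, or 4-hydroxyphenyl to phenyl.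

Within the data shown here, no measured step isolates this exchange. The only one available, a 3.8-fold lower number from compound 1 to compound 3 (0.58 log units; beyond the scatter), replaces phenyl with tert-butyl, so it gives only a rough, modest scale for a change of this kind. Like compound 4, compound 1 carries phenyl and gives 1710 nM, but it also differs from compound 2 elsewhere.

A modest move to a lower number is expected in this assay, estimated as a 2.4-fold lower number from compound 2 to compound 4 (0.38 log units; beyond the scatter). The expected value for compound 4 is 2000 nM, within an estimated range of 800 nM to 5000 nM.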

Compound 4, concentration for 50% growth inhibition: 180 nM
Compound 4: middle estimate off by 11-fold (1.05 log units), on the high side; measured number outside the range, below it.
By their numbers in this assay, from the lowest: compound 4; then compound 3; then compound 1; then compound 2.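

In this assay, among these compounds, hydrogen in place of hydroxy on the aromatic carbon para to a large group gives a 26-fold lower number from compound 2 to compound 4 (1.42 log units; beyond the scatter) and is the first large step, so the group at this position can strongly shift the read-out. With phenyl held constant, pyrrolidin-1-yl in place of piperidin-1-yl on the saturated chain carbon gives a 9.5-fold lower number from compound 1 to compound 4 (0.98 log units; beyond the scatter) as a second, modest step, so the result also depends on the group at that carbon. No measurement at hand explains either step.

On these data alone, it remains open whether methoxy or fluorine at the same aromatic carbon would behave like hydroxy or like hydrogen. Also open, as far as these compounds go, are how piperidin-1-yl behaves with 4-hydroxyphenyl in place and how a dimethylamino group on the chain carbon would compare.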